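Adding a 3-methoxyphenyl to compound 2

The source may report more compounds than this note shows. Statements on the series, on what has been measured and on what is new or still open speak of the compounds shown alone.

Compound 1 `O=C(CCc1cccc2c1B(O)OC2)Nc1ccccc1`: 30000 nM
Compound 2 `O=C(CCc1cccc2c1C(O)OC2)Nc1ccccc1`: 42000 nM

In an ADME assay on WI-38 cells (Homo sapiens) for cytotoxicity, read by MTT assay, with a stated time of 72 h (a higher number here means a weaker inhibitor, a lower number a stronger inhibitor), compound 2 gives 42000 nM, within the scatter of compound 1 at 30000 nM. Compound 3 `COc1cccc(-c2cccc(NC(=O)CCc3cccc4c3C(O)OC4)c2)c1` has not yet been measured. It departs from compound 2 by 3-methoxyphenyl in place of hydrogen on an aromatic carbon, with 3-methoxyphenyl in place of hydrogen on an aromatic carbon. Among the compounds with values here, no measured pair shows a change of this kind, so only a modest move toward a lower number is expected in this assay. The expected change is a 2.1-fold lower number from compound 2 to compound 3 (0.32 log units; beyond the scatter). Compound 3 is estimated at 20000 nM, within a range of 6000 nM to 60000 nM.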

Compound 3, half-maximal inhibitory concentration: 93000 nM
Compound 3: middle estimate off by 4.7-fold (0.67 log units), on the low side; measured number above the stated range.
By their numbers in this assay, from the lowest: compounds 1 and 2 (each within the scatter of the next); then compound 3.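

In this assay, 3-methoxyphenyl in place of hydrogen on an aromatic carbon, meta to a large group, gives a 2.2-fold higher number from compound 2 to compound 3 (0.35 log units; beyond the scatter) and so shows that this position can shift the number, here upward and beyond the scatter. The earlier pair differed at another place and stayed within the scatter. No measurement shown accounts for the rise. The compounds shown leave open whether a plain methoxy or an amine at this position would move the number the same way, and whether the step would hold on the core of compound 1.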